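Solubility notes on N-substituted pyridinium ketone series

A few compounds are considered here, and "the series" means these few. Any claim that something is new, unique, unknown or untested is made for them only; others in the source may bear on it.

Measured compounds:
compound 1 `CCC[n+]1ccc(CCC(=O)c2cc3cc(OC)c(OC)cc3s2)cc1` — 16000 ug/mL
compound 2 `CCOCC[n+]1ccc(CCC(=O)c2cc3cc(OC)c(OC)cc3s2)cc1` — 50000 ug/mL

In a physicochemical assay for solubility (a lower number here means a less soluble compound, a higher number a more soluble compound), compound 2 gives 50000 ug/mL and stands highest of the two numbers measured; its nearest neighbour is compound 1, which in this assay gives 16000 ug/mL, the difference being beyond the scatter.

Compound 3 `COC(=O)c1ccc(C[n+]2ccc(CCC(=O)c3cc4cc(OC)c(OC)cc4s3)cc2)cc1` is not yet measured. It differs from compound 2 by 4-(methoxycarbonyl)phenyl in place of ethoxymethyl on a saturated chain carbon bound to an aromatic nitrogen. Within the data shown here, the only measured step in this assay is a 3.1-fold higher number from compound 1 to compound 2 (0.49 log units; beyond the scatter), a modest rise that accompanied a change at the same saturated chain. The present change is larger and of another kind, so that step sets the scale but not the direction. A drop beyond the scatter is expected for compound 3, roughly a 6.3-fold lower number from compound 2 to compound 3 (0.80 log units; beyond the scatter) in this assay. Compound 3 is therefore estimated at 8000 ug/mL, with a range from 2000 ug/mL to 30000 ug/mL.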

Compound 3, solubility: 3500 ug/mL
For compound 3 the middle estimate is 2.3-fold (0.36 log units) above the measured one; the measured number falls inside the stated range.
By their numbers in this assay, from the lowest: compound 3; then compound 1; then compound 2.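

In this assay, the group on the saturated chain carbon bound to an aromatic nitrogen can also take the number down: a 14-fold lower number from compound 2 to compound 3 (1.15 log units; beyond the scatter), and a 4.6-fold lower number from compound 1 to compound 3 (0.66 log units; beyond the scatter), both beyond the scatter, which leaves compound 3 lowest of the three. Among these compounds, until now the only step at this place was a rise, a 3.1-fold higher number from compound 1 to compound 2 (0.49 log units; beyond the scatter), so the present change shows that the number moves in either direction with this group. No measurement on hand bears on why the number falls with 4-(methoxycarbonyl)phenyl.

The six-membered aromatic ring and the methoxycarbonyl group enter together, so the share of each in the drop stays unresolved. Going by these compounds, whether a plain benzyl or a 4-carboxybenzyl group at this place would read closer to compound 3 or to compound 2 also remains open.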